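The source may hold more compounds than are shown below. What is called first, only, known or untested is meant among the compounds shown, and "the series" means these compounds.

Three compounds are compared here in a functional assay on PC-3 cells (Homo sapiens) for cytotoxicity, read by sulforhodamine B assay, with a stated time of 72 h; a higher number here means a weaker inhibitor, a lower number a stronger inhibitor. Compound 1 `COc1ccc(/C=C/C(=O)/C=C(O)/C=C/c2ccc(OC(C)(C)C(=O)Nc3ccc(Cl)c(C(F)(F)F)c3)c(OC)c2)cc1OC` is reported only as a limit, > 100000 nM, and not as a number. Among the measured compounds shown here, compound 2 `COc1ccc(/C=C/C(=O)/C=C(O)/C=C/c2ccc(OCC(C)(O)C(=O)Nc3ccc([N+](=O)[O-])c(C(F)(F)F)c3)c(OC)c2)cc1OC` gives 39100 nM, which makes it the only compound so far with an actual number in this assay. For the measured compounds named here, its standing therefore cannot be judged against a second measured value, and no measured pair yet shows the size of a single structural change.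

The next compound, compound 3 `COc1ccc(/C=C/C(=O)/C=C(O)/C=C/c2ccc(OCC(C)(O)C(=O)Nc3ccc(C#N)c(C(F)(F)F)c3)c(OC)c2)cc1OC`, departs from compound 2 in one place: cyano in place of nitro on an aromatic carbon. The new group sits ortho to a trifluoromethyl group and para to a large group. With compound 2 at 39100 nM as the only anchor, no step beyond the usual scatter is expected in this assay, in either direction. The estimated change is small: a 1.0-fold higher number from compound 2 to compound 3 (0.01 log units; within the scatter). Compound 3 is expected to come in at about 40000 nM, with an estimated range from 15000 nM to 100000 nM.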

Compound 3, half-maximal inhibitory concentration: 100000 nM
Beside the measured number, compound 3's estimate is 2.5-fold (0.40 log units) below it; the range from low to high includes it.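

Replacing nitro with cyano on this aromatic carbon, ortho to a trifluoromethyl group and para to a large group, gives the first single change whose size can be read in this assay: a 2.6-fold higher number from compound 2 to compound 3 (0.41 log units; beyond the scatter). The step is modest, but it shows that the number responds to what stands at this position, even when one small group replaces another, and that of these two groups nitro goes with the stronger inhibitor. Compound 3 gives 100000 nM, so its number sits at the top of the range reported here, and the step should be read with that edge in mind: the limit of > 100000 nM in this assay, at which 1 of the 3 values shown sits.

A single pair cannot show why the number moves, nor whether the trend would hold on another version of the shared core, since only these two compounds differ in this one place. As far as these compounds go, it also remains open whether an amine, a carboxylic acid or a methyl ester on this same carbon would give a number lower than that of compound 2, which is still the stronger of the pair, or one that rises further.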